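Iodo for Isopropyl on the Pentylurea Sulfonate Core

A few compounds are considered here, and "the series" means these few. Any claim that something is new, unique, unknown or untested is made for them only; others in the source may bear on it.

Compound 1 `CCNC(=O)Nc1ccc(S(=O)(=O)Oc2ccccc2C(C)C)cc1` gives 10000 nM in a functional assay on MCF7 cells (Homo sapiens) for antiproliferative activity, read by sulforhodamine B assay, with a stated time of 48 h; a lower number here means a stronger inhibitor, a higher number a weaker inhibitor. Compound 2 `CCNC(=O)Nc1ccc(S(=O)(=O)Oc2ccccc2I)cc1` differs from it by iodo in place of isopropyl on an aromatic carbon and gives 1100 nM in this assay, so that the step is a 9.1-fold lower number from compound 1 to compound 2 (0.96 log units; beyond the scatter). Compound 3 `CCCCCNC(=O)Nc1ccc(S(=O)(=O)Oc2ccccc2C(C)C)cc1` rests on a different core; the difference from compound 1 is propyl in place of hydrogen on a saturated chain carbon, two bonds along the chain from an amide-type nitrogen, and compound 3 gives 4000 nM in this assay, which amounts to a 2.5-fold lower number from compound 1 to compound 3 (0.40 log units; beyond the scatter). Compound 4 `CCCCCNC(=O)Nc1ccc(S(=O)(=O)Oc2ccccc2I)cc1` has not yet been measured. It differs from compound 3 by iodo in place of isopropyl on an aromatic carbon, the same change that separates compound 2 from compound 1, made this time on the core of compound 3 rather than on the core of compound 1. Among these four compounds the change occurs twice, once measured and once still open. The expected step is an 8.9-fold lower number from compound 3 to compound 4 (0.95 log units; beyond the scatter) because a 9.1-fold lower number from compound 1 to compound 2 (0.96 log units; beyond the scatter) on the other core was of that order. Going by the values given here, compound 4 is therefore estimated at 450 nM in this assay, with a likely range from 150 nM to 1400 nM that allows for the usual scatter and for the single earlier example of this change.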

Compound 4, half-maximal inhibitory concentration: 5400 nM
Compound 4: the middle estimate sits 12-fold (1.08 log units) below what was measured, outside the stated range (above it).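

On the core of compound 3, iodo in place of isopropyl gives a 1.4-fold higher number from compound 3 to compound 4 (0.13 log units; within the scatter) in this assay, so the gain seen on the core of compound 1 does not reappear, and the two steps differ: the same change on two cores in this assay, a 9.1-fold lower number (0.96 log units; beyond the scatter) from compound 1 to compound 2 and a 1.4-fold higher number (0.13 log units; within the scatter) from compound 3 to compound 4, 12-fold (1.09 log units) apart, beyond the scatter of two such steps

Read along the other edge of the set, propyl in place of hydrogen on the chain gives a 4.9-fold higher number from compound 2 to compound 4 (0.69 log units; beyond the scatter), which runs the opposite way to the same change on the isopropyl compounds: the same change on two cores in this assay, a 2.5-fold lower number (0.40 log units; beyond the scatter) from compound 1 to compound 3 and a 4.9-fold higher number (0.69 log units; beyond the scatter) from compound 2 to compound 4, 12-fold (1.09 log units) apart, beyond the scatter of two such steps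

The two changes therefore do not add up across these four compounds, and a step measured on one core was no guide to the other, though this rests on a single pair of cores in one assay and does not show why the outcome depends on the core.

Still open, as far as these compounds go, is whether a butyl chain in place of the pentyl chain would keep the gain from iodo. Also open, from the compounds shown here alone, is whether bromo or chloro in place of iodo would behave alike on both cores.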